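The source may hold more compounds than are shown below. What is called first, only, known or untested is meant among the compounds shown, and "the series" means these compounds.

Measured so far in a physicochemical assay for pharmacokinetics, read by spectrophotometry, at 25 degrees C, at pH 7; a higher number here means that the compound lasts longer, a lower number that the compound disappears faster:

- compound 1 `O=C1C(Cl)=CC(=NBr)C=C1Cl` gives 3.7 h
- compound 2 `O=C1C(Cl)=CC(=NCl)C=C1Cl` gives 40 h
- compound 3 `O=C1C(Br)=CC(=NCl)C=C1Br` gives 23.3 h

Compound 4 `O=C1C(Br)=CC(=NBr)C=C1Br` is not yet measured in this assay.

The pair compound 2 and compound 1 differ by one change, (bromo in place of chloro on a double-bonded nitrogen), and this gave an 11-fold lower number from compound 2 to compound 1 (1.03 log units; beyond the scatter). The difference between the core of compound 2 and the core of compound 3 is not broken down here; their numbers in this assay lie within the scatter of each other. For the measured compounds named here, compound 4 is reached from compound 3 by bromo in place of chloro on a double-bonded nitrogen, the same change as the one made from compound 2 to compound 1, at a place described in identical words. It occurs twice among these compounds, and only one instance is measured.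

Expectation for compound 4 in this assay rests on that single measured instance: because an 11-fold lower number from compound 2 to compound 1 (1.03 log units; beyond the scatter) was large and beyond the scatter, a step of similar size is expected from compound 3, namely an 11-fold lower number from compound 3 to compound 4 (1.05 log units; beyond the scatter). On that basis compound 4 is estimated at 2.1 h, with a likely range from 0.8 h to 6 h.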

Compound 4, half-life: 10.4 h
Compound 4: the middle estimate sits 5.0-fold (0.69 log units) below what was measured; the measured number lies above the stated range.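

In this assay, bromo in place of chloro on a double-bonded nitrogen again lowers the number, with a 2.2-fold lower number from compound 3 to compound 4 (0.35 log units; beyond the scatter) set against an 11-fold lower number from compound 2 to compound 1 (1.03 log units; beyond the scatter): the direction carries from one core to the other, and both steps lie beyond the scatter, but the size does not carry, being large on the core of compound 2 and modest on the core of compound 3. Two instances show that, within these compounds, the direction of this change can be relied on more than its size; they do not establish a rule for any further core. Nothing at hand bears on why the size of the step differs between the two cores.

The compounds shown carry only chloro and bromo, so how a fluoro, an iodo or a methyl group on the double-bonded nitrogen would behave in this assay stays open. Also open, as far as these compounds go, is whether the change keeps its direction on a core carrying a methoxy group or an amine instead of the halogens.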